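Removing the hydroxymethyl from compound 1

The source may report more compounds than this note shows. Statements on the series, on what has been measured and on what is new or still open speak of the compounds shown alone.

Compound 1 `OCc1cc(N2CCCC2)ccc1-c1nc2c(s1)C(O)CCC2`: 56 nM
Compound 2 `OC1CNCc2nc(-c3ccc(N4CCCC4)cc3)sc21`: 1530 nM
Compound 3 `Cc1cc(N(C)C)ccc1-c1nc2c(s1)[C@H](O)CCC2`: 730 nM

In a functional assay on MCF7 cells (Homo sapiens) for cytotoxicity, read by sulforhodamine B assay, with a stated time of 2 days (a lower number here means a stronger inhibitor, a higher number a weaker inhibitor), compound 1 gives 56 nM, the lowest of the three numbers; compound 3 gives 730 nM and compound 2 gives 1530 nM, both beyond the scatter from it. Compound 4 `OC1CCCc2nc(-c3ccc(N4CCCC4)cc3)sc21` differs from compound 1 in one place: hydrogen in place of hydroxymethyl on an aromatic carbon. Going by the values given here, no measured pair isolates this change. Compound 3, with a different group at that place and a different amine, sits far weaker, and compound 2, unsubstituted there but with another core, weaker still. The step from compound 1 to compound 4 is therefore expected to run toward weaker inhibition, a 5.4-fold higher number from compound 1 to compound 4 (0.73 log units; beyond the scatter). Compound 4 is estimated at 300 nM, within 80 nM to 1200 nM.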

Compound 4, half-maximal inhibitory concentration: 8700 nM
Beside the measured number, compound 4's estimate is 29-fold (1.46 log units) below it; the measured number lies above the stated range.
By their numbers in this assay, from the lowest: compound 1; then compound 3; then compound 2; then compound 4.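

In this assay, going by these compounds alone, this is the first pair to isolate the aromatic carbon ortho to a large group, and the position proves highly sensitive to the change: hydrogen in place of hydroxymethyl gives a 160-fold higher number from compound 1 to compound 4 (2.19 log units; beyond the scatter), a large step beyond the scatter. On the shared core with the pyrrolidin-1-yl group, the hydroxymethyl is therefore tied to a large part of the activity of compound 1. Nothing measured here explains this loss. From the compounds shown here alone, it remains open whether the hydroxymethyl itself is required at this place. An aminomethyl group, a methoxymethyl group or a longer hydroxyalkyl chain there would test how specific the step is.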